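Swapping Butylcarbonyl for Methyl on Compound 2

The source may report more compounds than this note shows. Statements on the series, on what has been measured and on what is new or still open speak of the compounds shown alone.

Compounds measured in a functional assay on THP-1 cells (Homo sapiens) for inhibition, with a stated time of 48 h, tested at 50 uM; on this read-out lower numbers stand for less inhibition of growth and higher numbers for more inhibition of growth at the one concentration tested
- compound 1 `C=C[C@@](C)(/C=C/c1ccc(OC(C)=O)cc1)CCC=C(C)C` gives 81%
- compound 2 `C=C[C@@](C)(/C=C/c1ccc(OC(=O)CCCC)cc1)CCC=C(C)C` gives 15%
- compound 3 `C=C[C@@](C)(/C=C/c1ccc(OC(=O)CCCCCCCCCCCCCCC)cc1)CCC=C(C)C` gives 62%

Among these three, compound 2 stands lowest, and its steps to both others lie beyond the scatter. The unmeasured compound 4 `C=C[C@@](C)(/C=C/c1ccc(OC)cc1)CCC=C(C)C` differs from compound 2 in one place, with methyl in place of butylcarbonyl on an oxygen on an aromatic ring. Going by the values given here, no measured step makes this exact change: all three measured compounds carry a carbonyl on that oxygen, and compound 4 does not. The two steps that bear on it alter only the chain on that carbonyl, and both are large (a number 66 percentage points lower from compound 1 to compound 2 (beyond the scatter)) and (a number 47 percentage points higher from compound 2 to compound 3 (beyond the scatter)). Compound 1 (81%) and compound 3 (62%) both lie well above compound 2, so a change at this place is more likely to raise the number than to lower it, although no direct comparison secures that direction. The expected step is therefore a fairly large one upward (a number 35 percentage points higher from compound 2 to compound 4 (beyond the scatter)). Compound 4 is estimated at 50% within a range of 20% to 85% in this assay as the expected outcome.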

Compound 4, percent growth inhibition at one concentration: 45%
Estimate against measurement, compound 4: 5 percentage points above, within the range that was stated.
By their numbers in this assay, from the lowest: compound 2; then compound 4; then compound 3; then compound 1.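

In this assay, going by these compounds alone, compound 4 is the first compound here without a carbonyl on the oxygen on the aromatic ring, and it shows that growth inhibition at the one concentration tested does not depend on that carbonyl being present. Replacing the acyl group with methyl has no single direction: replacing butylcarbonyl gives a number 30 percentage points higher from compound 2 to compound 4 (beyond the scatter), whereas replacing acetyl gives a number 36 percentage points lower from compound 1 to compound 4 (beyond the scatter), so the outcome of the same methyl at this place depends on which group leaves. Nothing available here explains why the two steps run in opposite directions.

From the compounds shown here alone, it remains open how a free hydroxyl on the aromatic ring, or a longer chain such as butyl joined directly to that oxygen without a carbonyl, would compare with methyl. The compounds shown also leave open whether chains of intermediate length on the carbonyl would fall close to compound 2 or rise steadily towards compound 3, and whether any of these differences would hold at other concentrations.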